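Working notes: trifluoromethoxy exchanged for (trifluoromethyl)sulfanyl

A few compounds are considered here, and "the series" means these few. Any claim that something is new, unique, unknown or untested is made for them only; others in the source may bear on it.

- compound 1 `C=C(Br)C(=O)Nc1cccc(/C=C/C(=O)Nc2ccc(F)cc2)c1`: 36600 nM
- compound 2 `C=C(Br)C(=O)Nc1cccc(/C=C/C(=O)Nc2ccc(OC(F)(F)F)cc2)c1`: 61200 nM

Both values come from a functional assay on HT-29 cells (Homo sapiens) for inhibition, read by MTT assay, with a stated time of 72 h; a higher number here means a weaker inhibitor, a lower number a stronger inhibitor. Compound 2 stands within the scatter of compound 1, and only these two numbers are available so far. Compound 3 `C=C(Br)C(=O)Nc1cccc(/C=C/C(=O)Nc2ccc(SC(F)(F)F)cc2)c1` is still unmeasured, and its difference from compound 2 is (trifluoromethyl)sulfanyl in place of trifluoromethoxy on an aromatic carbon. Among the compounds with values here, the single measured step that bears on this aromatic carbon is a 1.7-fold higher number from compound 1 to compound 2 (0.22 log units; within the scatter). On the evidence of that small step, no change beyond the scatter is expected in this assay. The expected step is a 1.2-fold lower number from compound 2 to compound 3 (0.09 log units; within the scatter). Compound 3 is estimated at 50000 nM, with an expected range of 24000 nM to 100000 nM.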

Compound 3, half-maximal inhibitory concentration: 39800 nM
The estimate for compound 3 lay 1.3-fold (0.10 log units) above the measured number, and the stated range covers the measured number.
By their numbers in this assay, from the lowest: compounds 1, 3 and 2 (each within the scatter of the next).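

In this assay, the exchange at this aromatic carbon gives a 1.5-fold lower number from compound 2 to compound 3 (0.19 log units; within the scatter), and the comparison with fluoro gives a 1.1-fold higher number from compound 1 to compound 3 (0.04 log units; within the scatter). Fluoro, trifluoromethoxy and (trifluoromethyl)sulfanyl therefore all stand within the scatter of one another, and exchanging oxygen for sulfur in this group does not separate the compounds. Nothing at hand offers an explanation for this result.

From the compounds shown here alone, whether an amine, a carboxylic acid or a longer alkyl chain on this carbon would move the number beyond the scatter remains open. Also open, going by these compounds, is whether the same holds with changes elsewhere on the shared core.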